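Swapping methyl for chloro on an inactive pair

The compounds below may be only part of what the source reports. "The series", "measured", "known", "first", "only" and "open" are said of these compounds alone.

Compound 1, `CC(C)(C)c1ccc(-c2nn(CCCN3CCN(c4cccc(Cl)c4)CC3)c(=S)[nH]2)cc1`: in a functional assay on THP-1 cells (Homo sapiens) for cytotoxicity, read by MTT assay, with a stated time of 24 h (a lower number here means a stronger inhibitor, a higher number a weaker inhibitor), compound 1 gives > 300000 nM, which is a limit of the assay rather than a number.
Compound 2, `Cc1ccc(-c2nn(CCCN3CCN(c4cccc(Cl)c4)CC3)c(=S)[nH]2)cc1`: in this assay compound 2 gives > 300000 nM, again a limit of the assay.

Compound 2 therefore stands only at a limit, and the same holds for compound 1. Within the data shown here, both values shown sit at the limit of > 300000 nM in this assay, at which 2 of the 2 values shown sit, so the single measured step, a step that the two limits leave unreadable from compound 1 to compound 2, cannot be read in size or direction.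

Compound 3, `S=c1[nH]c(-c2ccc(Cl)cc2)nn1CCCN1CCN(c2cccc(Cl)c2)CC1`, differs from compound 2 by chloro in place of methyl on an aromatic carbon. Among the measured compounds shown here, no measured step bears directly on this change: the only step compares two compounds that both rest at the limit, and it tells nothing about whether a small change on this ring moves the value. With no readable step in this assay, no shift beyond the scatter can be expected in either direction. The step from compound 2 to compound 3 is expected to be a number no higher from compound 2 to compound 3 (the limit leaves the size open). Compound 3 is therefore estimated at 300000 nM, within a range from 100000 nM to 1000000 nM, most likely reported again as a limit.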

Compound 3, half-maximal inhibitory concentration: > 300000 nM
Compound 3: only a limit was reported; the forecaster's own chance of this, stated with the estimate: 85%; the middle value sits exactly at the limit.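

Compound 3 also rests at a limit of the assay rather than at a number, so the steps to it from compound 1 and compound 2 cannot be read in size or direction: the limit of > 300000 nM in this assay, at which 3 of the 3 values shown sit.

The three compounds leave open whether any group at this place on the ring can move the value in this assay.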